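The compounds below may be only part of what the source reports. "The series", "measured", "known", "first", "only" and "open" are said of these compounds alone.

The compounds here share one core, seen in compound 1 `CCCNc1nc(N)nc2c1ncn2/C=C1/CC1(CO)CO`, compound 2 `Nc1nc(NCc2ccccc2)c2ncn(/C=C3/CC3(CO)CO)c2n1` and compound 3 `CCCCCOc1nc(N)nc2c1ncn2/C=C1/CC1(CO)CO`. They were examined in an ADME assay on MOLT-3 cells (Homo sapiens) for cytotoxicity, with a stated time of 7 days; a lower number here means that less compound is tolerated, a higher number that more compound is tolerated. For compound 1 no result is given in this assay; its entry reads "not determined" (no result reported). For compound 2 this assay gives a limit of the test and not a number: > 20000 nM. For compound 3 this assay likewise gives only a limit: > 20000 nM. The step that the two limits leave unreadable from compound 2 to compound 3 cannot be sized; both of its ends are limits. What the two readings share is the limit of > 20000 nM in this assay, at which 2 of the 3 values shown sit.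

The unmeasured compound 4 `CCCSc1nc(N)nc2c1ncn2/C=C1/CC1(CO)CO` is compound 1 with one change: propylsulfanyl in place of propylamino on an aromatic carbon. Going by the values given here, no measured step touches a propylamino group or a propylsulfanyl group, and compound 1 itself has no number to start from. All that is known is that neither compound with a reading reached a measurable level within the range of this assay.

Compound 4 is therefore expected, most likely, to return the same limit rather than a number, and the estimate for it is 30000 nM, with a range from 10000 nM to 100000 nM.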

Compound 4, half-maximal cytotoxic concentration: > 20000 nM
Compound 4: no number, only a limit; the forecaster's own chance of this, stated with the estimate: 85%; the middle value is on the limit's open side.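

The steps to compound 4 from compound 2 and from compound 3 cannot be read, as all three compounds end at the same reading: the limit of > 20000 nM in this assay, at which 3 of the 4 values shown sit. What the compounds shown leave open is whether any group at this place on the shared core gives a measurable number in this assay, and where compound 1, with its propylamino group, stands.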